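Shortening the carbamate chain on a selenocyanate

A few compounds are considered here, and "the series" means these few. Any claim that something is new, unique, unknown or untested is made for them only; others in the source may bear on it.

Measured compounds:
Compound 1 `CCCCOC(=O)Nc1ccc([Se]C#N)cc1`: 40800 nM
Compound 2 `CCOC(=O)Nc1ccc([Se][Se]c2ccc(NC(=O)OCC)cc2)cc1`: 52200 nM

This account follows two aryl selenium compounds in a functional assay on PC-3 cells (Homo sapiens) for cytotoxicity, read by MTT assay, with a stated time of 72 h; a higher number here means a weaker inhibitor of growth, a lower number a stronger inhibitor of growth. Compound 1 carries a butyl carbamate on a selenocyanate-bearing core and gives 40800 nM in this assay. Compound 2, a diselenide with an ethyl carbamate on each half, gives 52200 nM. Compound 1 gives the lower of the two numbers, but the gap to compound 2 lies within the scatter of this assay, so the two cannot be told apart.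

The unmeasured compound 3 `CCOC(=O)Nc1ccc([Se]C#N)cc1` is compound 1 with a shorter chain: hydrogen in place of ethyl on a saturated chain carbon, two bonds along the chain from an oxygen next to a carbonyl group. Among the compounds with values here, no step between measured compounds covers this kind of change, so nothing in the data shows how the carbamate chain length matters. Given that compound 2 with its ethyl carbamates gives 52200 nM, close to compound 1, only a small step is expected, none beyond the scatter. Compound 3 is therefore estimated at 50000 nM, with a range of 20000 nM to 125000 nM, which means an expected step of a 1.2-fold higher number from compound 1 to compound 3 (0.09 log units; within the scatter).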

Compound 3, concentration for total growth inhibition: 39200 nM
Compound 3: middle estimate off by 1.3-fold (0.11 log units), on the high side; the range from low to high includes it.
By their numbers in this assay, from the lowest: compounds 3, 1 and 2 (each within the scatter of the next).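

Within the data shown here, compound 1 and compound 3 are the first pair in this account that differs in one place, and in this assay hydrogen in place of ethyl gives a 1.0-fold lower number from compound 1 to compound 3 (0.02 log units; within the scatter) for that pair. At this position, on a saturated chain carbon, two bonds along the chain from an oxygen next to a carbonyl group, going from the butyl carbamate to the ethyl carbamate therefore produces no difference that this assay can resolve on the selenocyanate-bearing core. The data shown offer no measurement that could account for this result.

The shown chains are only butyl and ethyl, so it remains open whether the same holds for a longer chain such as octyl, or for a chain ending in an amine or a carboxylic acid. Among these compounds, no single-place step links a selenocyanate to the diselenide, so what the selenium group itself contributes to the read-out cannot be judged from these compounds.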